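Ester side chain change in a small series

The source may hold more compounds than are shown below. What is called first, only, known or untested is meant among the compounds shown, and "the series" means these compounds.

Measured so far in a functional assay on RAW264.7 cells (Mus musculus), read by Griess assay, with a stated time of 15 min (a lower number here means a stronger inhibitor, a higher number a weaker inhibitor), are:
- compound 1 `C/C=C(\C)C(=O)O[C@H]1C[C@@H](C)[C@]2(O)CC[C@](C)(/C=C3/OC(=O)C(COC(C)=O)=C31)O2` at 2000 nM
- compound 2 `C=C(C)C(=O)O[C@H]1C[C@@H](C)[C@]2(OC)CC[C@](C)(/C=C3/OC(=O)C(COC(C)=O)=C31)O2` at 1500 nM

Compound 2 at 1500 nM stands within the scatter of compound 1, and the two cannot be ranked. Against compound 2 the change in compound 3 `C/C=C(\C)C(=O)O[C@H]1C[C@@H](C)[C@]2(OC)CC[C@](C)(/C=C3/OC(=O)C(COC(C)=O)=C31)O2` is 1-methylprop-1-en-1-yl in place of 1-methylethenyl on a carbonyl carbon and reads 1-methylprop-1-en-1-yl in place of 1-methylethenyl on a carbonyl carbon. Going by the values given here, no measured pair isolates this change, and no shift beyond the scatter is expected in this assay for it. The expected move is a 1.1-fold higher number from compound 2 to compound 3 (0.05 log units; within the scatter) on this estimate. Compound 3 is estimated at 1700 nM with an expected range from 800 nM to 3600 nM overall.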

Compound 3, half-maximal inhibitory concentration: 1200 nM
Compound 3: middle estimate off by 1.4-fold (0.15 log units), on the high side; low and high end bracket the measured number.
By their numbers in this assay, from the lowest: compounds 3, 2 and 1 (each within the scatter of the next).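

In this assay, 1-methylprop-1-en-1-yl in place of 1-methylethenyl on a carbonyl carbon gives a 1.3-fold lower number from compound 2 to compound 3 (0.10 log units; within the scatter), so the two groups cannot be told apart at this position. Methyl in place of hydrogen on an oxygen on a saturated carbon gives a 1.7-fold lower number from compound 1 to compound 3 (0.22 log units; within the scatter), and that change cannot be resolved either. Nothing available accounts for these readings.

Open, going by these compounds, is whether an amine, a carboxylic acid or a longer chain at this ester position would produce a step beyond the scatter.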